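From thiophen-2-yl to butyl on a sulfonyl sulfur

This account rests on a few compounds, and the source may have more. Where it says the series, first, only, none or still open, it means among the compounds named here.

Measured in a functional assay for inhibition, with Homo sapiens as the target; a higher number here means a weaker inhibitor, a lower number a stronger inhibitor:
- compound 1 `O=C(NC[C@H](NS(=O)(=O)c1cccnc1)C(=O)O)c1cc2cc(CC3CCNCC3)sc2s1`: 23 nM
- compound 2 `O=C(NC[C@H](NS(=O)(=O)c1cccnc1)C(=O)O)c1cc2cc(CCCC3CCNCC3)sc2s1`: 21 nM
- compound 3 `O=C(NC[C@H](NS(=O)(=O)c1cccs1)C(=O)O)c1cc2cc(CCC3CCNCC3)sc2s1`: 9 nM

Compound 3 has the lowest number of the three, and its gaps to compound 1 and compound 2 both lie beyond the scatter. Compound 4 `CCCCS(=O)(=O)N[C@@H](CNC(=O)c1cc2cc(CCC3CCNCC3)sc2s1)C(=O)O` differs from it in one place, with butyl in place of thiophen-2-yl on a sulfonyl sulfur. Within the data shown here, the only measured single-place step is a 1.1-fold lower number from compound 1 to compound 2 (0.04 log units; within the scatter). It lies within the scatter and concerns the chain carrying the piperidine, so it says nothing direct about this change. Among the measured compounds shown here, no measured pair isolates the group on the sulfonyl sulfur. Compound 1 and compound 2 differ from compound 3 in that group and in the chain, so the comparison of compound 2 at 21 nM with compound 3 at 9 nM is only a loose guide. A modest move to a higher number is therefore expected, and the expected step is a 1.6-fold higher number from compound 3 to compound 4 (0.19 log units; within the scatter). The estimated value for compound 4 is 14 nM, with an expected range of 6 nM to 35 nM.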

Compound 4, half-maximal inhibitory concentration: 32 nM
The estimate for compound 4 lay 2.3-fold (0.36 log units) below the measured number; low and high end bracket the measured number.
By their numbers in this assay, from the lowest: compound 3; then compounds 2, 1 and 4 (each within the scatter of the next).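

In this assay, butyl in place of thiophen-2-yl on a sulfonyl sulfur gives a 3.6-fold higher number from compound 3 to compound 4 (0.55 log units; beyond the scatter) and, unlike the earlier step within the chain carrying the piperidine, this one lies beyond the scatter. Among these compounds, it is the first direct reading of this position and shows that the group on the sulfonyl sulfur affects this read-out when the rest of the structure stays the same, with the five-membered aromatic ring giving the lower number and the open butyl chain the higher one. No measurement shown accounts for this difference.

The compounds shown leave open whether phenyl, or a shorter chain such as methyl, on the sulfonyl sulfur would stand nearer to compound 3 or to compound 4. They also leave open whether the same step would appear with the other chain lengths on the piperidine side.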